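The source may hold more compounds than are shown below. What is called first, only, known or untested is meant among the compounds shown, and "the series" means these compounds.

Compound 3 `O=C1c2ccccc2N(Cc2ccccc2)S(=O)(=O)N1Cc1ccccc1Cl` stands at a limit in a functional assay on HEL cells (Homo sapiens) for inhibition; on this read-out lower numbers stand for higher toxicity in this test and higher numbers for lower toxicity in this test: compound 3 gives > 200000 nM, which is a limit of the assay and not a number, namely (the limit of > 200000 nM in this assay, at which 1 of the 3 values shown sits). Of the three values shown, one further value is also a limit. Within the data shown here, the only measured step reaching compound 3 is an at least 1.6-fold higher number from compound 1 to compound 3 (0.21 log units; that floor lies within the scatter), and compound 1 `O=C1c2ccccc2N(Cc2ccccc2)S(=O)(=O)N1Cc1ccc(Cl)cc1` gives 121000 nM in this assay. Compound 2 `O=C1c2ccccc2N(Cc2ccccc2Cl)S(=O)(=O)N1COCc1ccccc1` already carries the (benzyloxy)methyl group. In this assay compound 2 gives > 50000 nM, again a limit, namely (the limit of > 50000 nM in this assay, at which 1 of the 3 values shown sits). Compound 4 `O=C1c2ccccc2N(Cc2ccccc2)S(=O)(=O)N1COCc1ccccc1` differs from compound 3 by benzyloxy in place of 2-chlorophenyl on a saturated chain carbon bound to an amide-type nitrogen in a ring. Among the measured compounds shown here, no measured step covers this exchange directly: the step of an at least 1.6-fold higher number from compound 1 to compound 3 (0.21 log units; that floor lies within the scatter) concerns only the 4-chlorophenyl to 2-chlorophenyl exchange and lies within the scatter, and compound 2 and compound 4 share the entering group while differing elsewhere. Both limits point to weak cytotoxicity throughout, so the expected step is an at least 1.3-fold lower number from compound 3 to compound 4 (0.12 log units; that floor lies within the scatter), with a good chance that compound 4 again ends at a limit. Compound 4 is estimated at 150000 nM, between 50000 nM and 300000 nM.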

Compound 4, half-maximal cytotoxic concentration: > 98000 nM
Compound 4 was reported as a limit; the forecaster's own chance of this, stated with the estimate: 65%; the middle value does not contradict the limit.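

In this assay compound 4 gives > 98000 nM, a limit of the assay and not a number. The steps to compound 4 from compound 1, compound 2 and compound 3 cannot be read. The compounds shown leave open how far benzyloxy and 2-chlorophenyl differ in this assay, and where compound 2, compound 3 and compound 4 actually lie.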